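This account rests on a few compounds, and the source may have more. Where it says the series, first, only, none or still open, it means among the compounds named here.

Among the measured compounds shown here, compound 1 `O=C(NC1CCCC(NC(=O)c2ccccn2)C1)c1cccc(Cl)c1` is the anchor of this small series: in a functional assay on HEK293 cells for antagonist activity at metabotropic glutamate receptor 5 (Homo sapiens), read by FLIPR and calcium flux (a lower number here means a stronger inhibitor, a higher number a weaker inhibitor), compound 1 gives 314 nM, and it is the only compound with a number rather than a limit. Compound 2 `O=C(N[C@H]1CCC[C@H](NC(=O)c2ccccn2)C1)c1cccc(Cl)c1`, drawn with both ring stereocentres defined, returns only a limit of > 10000 nM in this assay. Compound 3 `COc1cccc(C(=O)NC2CCCC(NC(=O)c3ccccn3)C2)c1` likewise returns only a limit of > 10000 nM. The step of an at least 31-fold higher number from compound 1 to compound 2 (1.50 log units; beyond the scatter) and the step of an at least 31-fold higher number from compound 1 to compound 3 (1.50 log units; beyond the scatter) are therefore both large, though their true size is hidden by the limit of > 10000 nM in this assay, at which 2 of the 3 values shown sit.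

Compound 4 `O=C(NC1CCCC(NC(=O)c2cccc(Cl)c2)C1)c1cccc(Cl)c1` differs from compound 1 in one place: 3-chlorophenyl in place of pyridin-2-yl on a carbonyl carbon. For the measured compounds named here, neither measured step touches the pyridin-2-yl side of the core, so no step bears directly on it; what the measured steps do show is that compound 1 tolerated neither change tried so far. On that basis a loss in this assay is expected for compound 4, estimated at a 6.4-fold higher number from compound 1 to compound 4 (0.80 log units; beyond the scatter), with compound 4 expected near 2000 nM within a range of 500 nM to 10000 nM.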

Compound 4, half-maximal inhibitory concentration: 139 nM
Beside the measured number, compound 4's estimate is 14-fold (1.16 log units) above it, outside the stated range (below it).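

In this assay the swap on the carbonyl carbon gives a 2.3-fold lower number from compound 1 to compound 4 (0.35 log units; beyond the scatter), the first step shown on this side of the core and the first from compound 1 toward a stronger inhibitor. The entering 3-chlorophenyl carries no hydrogen-bond acceptor where the leaving pyridin-2-yl carries one, so an acceptor in this ring is not required for activity at this level. Nothing given here accounts for the size or direction of this step.

Still open, from the compounds shown here alone, is whether the chlorine or the all-carbon ring carries the step, which an unsubstituted phenyl or a 3-fluorophenyl at this place would help separate. Also open, going by these compounds, is how a saturated group such as cyclohexyl would fare here, and how compound 4 would behave with its ring stereocentres defined.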